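The source may hold more compounds than are shown below. What is called first, only, known or untested is meant among the compounds shown, and "the series" means these compounds.

Measured in a toxicity assay on MDCK cells (Canis lupus familiaris) for cytotoxicity, read by crystal violet staining, with a stated time of 48 h; a higher number here means that more compound is tolerated, a lower number that less compound is tolerated:
- Compound 1 `Cc1ccc2[nH]c(=O)c(CN(Cc3ccc(F)cc3)Cc3ccc(C(C)(C)C)cc3)cc2c1`: > 27000 nM, a limit
- Compound 2 `CCCc1ccc2[nH]c(=O)c(CN(Cc3ccc(F)cc3)Cc3ccc(C(C)(C)C)cc3)cc2c1`: 8400 nM
- Compound 3 `Cc1ccc2[nH]c(=O)c(CN(Cc3ccc(F)cc3)Cc3cccc4ccccc34)cc2c1`: > 5000 nM, a limit

In this assay compound 1 has no exact number and stands only at the limit of > 27000 nM. Compound 4 `COCOc1ccc(CN(Cc2ccc(C(C)(C)C)cc2)Cc2cc3cc(C)ccc3[nH]c2=O)cc1` differs from it in one place: methoxymethoxy in place of fluoro on an aromatic carbon. Methoxymethoxy takes the place of fluoro on an aromatic carbon.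

Neither measured step touches that place. One is an at least 3.2-fold lower number from compound 1 to compound 2 (0.50 log units; beyond the scatter), with ethyl in place of hydrogen on a saturated chain carbon. The other is a step that the two limits leave unreadable from compound 1 to compound 3. Only a modest step to a lower number, or none, is therefore expected in this assay. The estimated change is an at least 1.2-fold lower number from compound 1 to compound 4 (0.08 log units; that floor lies within the scatter). Compound 4 is expected at 22000 nM, within an estimated range of 8000 nM to 60000 nM.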

Compound 4, half-maximal cytotoxic concentration: 6400 nM
Estimate against measurement, compound 4: 3.4-fold (0.54 log units) above, outside the stated range (below it).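

In this assay, methoxymethoxy in place of fluoro gives an at least 4.2-fold lower number from compound 1 to compound 4 (0.62 log units; beyond the scatter). This is the first change shown on this aromatic carbon, and it shows that a replacement of fluoro here can lower the number beyond the scatter. The step is only a floor, because compound 1 has no exact number and stands at a limit: the limit of > 27000 nM in this assay, at which 1 of the 4 values shown sits.

The compounds shown leave open whether a hydroxyl or a methoxy group on this carbon would give a similar step. They also leave open how an amine or a carboxylic acid there would read.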